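Removing the Benzoyl Group from a Weak Cytotoxic Amide

The source may hold more compounds than are shown below. What is called first, only, known or untested is meant among the compounds shown, and "the series" means these compounds.

Compound 1 `O=C(NCc1ccc(F)cc1)c1nc(Br)c2cccnc2c1NCc1ccccc1`: > 20000 nM (a limit)
Compound 2 `NCCCNc1c(C(=O)NCc2ccc(F)cc2)ncc2cccnc12`: 16000 nM
Compound 3 `O=C(NCCCNc1c(C(=O)NCc2ccc(F)cc2)nc(Br)c2cccnc12)c1ccccc1`: > 20000 nM (a limit)

In a functional assay on MDA-MB-435 cells (Homo sapiens) for cytotoxicity, read by MTT assay, with a stated time of 72 h (a lower number here means a stronger inhibitor, a higher number a weaker inhibitor), compound 3 gives only a limit, > 20000 nM, with no number beneath it. Compound 1 likewise gives only a limit in this assay. Compound 2, with its free amine, gives a measured number. Compound 4 `NCCCNc1c(C(=O)NCc2ccc(F)cc2)nc(Br)c2cccnc12` differs from compound 3 by hydrogen in place of benzoyl on an amine nitrogen. Going by the values given here, the one measured step, a step that the two limits leave unreadable from compound 1 to compound 3, cannot be sized, since both ends sit at the limit of > 20000 nM in this assay, at which 2 of the 3 values shown sit. So no measured step bears on this change, and the expectation rests on compound 2, which is estimated to be closest, because compound 2 gives 16000 nM. Compound 4 is therefore expected to remain weak, with the step of an at least 1.1-fold lower number from compound 3 to compound 4 (0.04 log units; that floor lies within the scatter) expected to stay within the scatter. Compound 4 is estimated at 18000 nM, between 8000 nM and 40000 nM.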

Compound 4, half-maximal inhibitory concentration: 5000 nM
Estimate against measurement, compound 4: 3.6-fold (0.56 log units) above; measured number outside the range, below it.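

In this assay hydrogen in place of benzoyl on an amine nitrogen gives an at least 4.0-fold lower number from compound 3 to compound 4 (0.60 log units; beyond the scatter) and so offers the first readable sign that what sits on this nitrogen matters. With the free amine kept, bromo in place of hydrogen on an aromatic carbon gives a 3.2-fold lower number from compound 2 to compound 4 (0.51 log units; beyond the scatter) and 2-aminoethyl in place of phenyl gives an at least 4.0-fold lower number from compound 1 to compound 4 (0.60 log units; beyond the scatter) as well. The steps from compound 3 and from compound 1 are only minimum sizes, since both compounds sit at a limit: the limit of > 20000 nM in this assay, at which 2 of the 4 values shown sit.

As far as these compounds go, whether an acetyl group on that nitrogen, a dimethylamino group in place of the amino group, or a longer chain would give a lower number stays open.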